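A few compounds are considered here, and "the series" means these few. Any claim that something is new, unique, unknown or untested is made for them only; others in the source may bear on it.

Compound 1, with the structure `c1ccc(Nc2ccc(N3CC4CC(C3)N4)cn2)cc1`, is a potent ligand in an assay on cell membranes for displacement of a labelled ligand from Neuronal acetylcholine receptor; alpha4/beta2 (Rattus norvegicus) (a higher number here means a weaker inhibitor, a lower number a stronger inhibitor), where compound 1 gives 2.66 nM. Among the three compounds measured, compound 1 stands second highest: compound 3, with the structure `Fc1ccc(Nc2cncc(N3CC4CC(C3)N4)c2)cc1`, gives 0.091 nM in this assay, a lower number beyond the scatter, while compound 2, with the structure `Fc1ccc(Nc2ccc(N3CC4CC(C3)N4)nn2)cc1`, gives 868 nM, a far higher number, also beyond the scatter. Among the compounds with values here, neither of these two shares its core with compound 1, so no single-point step between measured compounds is available.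

Compound 4, with the structure `Clc1ccc(Nc2ccc(N3CC4CC(C3)N4)cn2)cc1`, differs from compound 1 in one place: chloro in place of hydrogen on an aromatic carbon. The change sits on an aromatic carbon of a six-membered aromatic ring of carbon only, para to a large group, and otherwise leaves the molecule unchanged.

Within the data shown here, with no measured step of this kind to lean on, the account expects a small step, from compound 1 to compound 4 of a 1.7-fold lower number from compound 1 to compound 4 (0.22 log units; within the scatter), likely within the scatter or a modest move toward a lower number. Compound 4 is therefore expected to give about 1.6 nM in this assay, within a range from 0.4 nM to 6 nM.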

Compound 4, inhibition constant: 2.49 nM
Compound 4: the middle estimate sits 1.6-fold (0.19 log units) below what was measured, within the range that was stated.
By their numbers in this assay, from the lowest: compound 3; then compounds 4 and 1 (each within the scatter of the next); then compound 2.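

In this assay, within the data shown here, chloro in place of hydrogen gives a 1.1-fold lower number from compound 1 to compound 4 (0.03 log units; within the scatter), the first step that can be read at a single place. It shows that on this aromatic carbon of the six-membered aromatic ring of carbon only, para to a large group, the change from phenyl to 4-chlorophenyl leaves the number within the scatter. No measurement bearing on this result is available to explain it.

The compounds shown leave open whether this holds for other groups at the same place, such as methoxy, an amine or a carboxylic acid. They also leave open whether chloro at this place would give the same small step on the cores of compound 2 and compound 3.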